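The source may report more compounds than this note shows. Statements on the series, on what has been measured and on what is new or still open speak of the compounds shown alone.

Three compounds share one core and differ only in the group carried on a nitrogen attached to that core. Compound 1 `C#CCSc1nc(NCCC(C)C)c2ccncc2n1` carries an isopentyl chain there. In a functional assay on HepG2 cells (Homo sapiens) for inhibition, read by MTT assay, with a stated time of 72 h (a higher number here means a weaker inhibitor, a lower number a stronger inhibitor), compound 1 gives > 80000 nM, which is a limit of the assay rather than a number. Compound 2 `C#CCSc1nc(NCCC#N)c2ccncc2n1` carries a 2-cyanoethyl chain in the same place, and in this assay compound 2 also gives > 80000 nM, again a limit. Among the compounds with values here, compound 3 `C#CCSc1nc(Nc2ccc(C)cc2)c2ccncc2n1` carries a 4-methylphenyl group on that nitrogen, and in this assay compound 3 gives 6170 nM, the only value among the three that is a number. The step from compound 1 to compound 3 reads an at least 12-fold lower number from compound 1 to compound 3 (1.11 log units; beyond the scatter), and the step from compound 2 to compound 3 reads an at least 12-fold lower number from compound 2 to compound 3 (1.11 log units; beyond the scatter), both of which rest on (the limit of > 80000 nM in this assay, at which 2 of the 3 values shown sit). The two limits leave the step that the two limits leave unreadable from compound 1 to compound 2.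

Compound 4 `C#CCSc1nc(Nc2ccc(F)cc2)c2ccncc2n1` has not yet been measured in this assay. It differs from compound 3 in one place: fluoro in place of methyl on an aromatic carbon, so that 4-methylphenyl becomes 4-fluorophenyl. Within the data shown here, none of the measured steps touches this ring; each of them swaps a chain for the whole ring, so they say nothing direct about changing one group on it. The step from compound 3 to compound 4 is therefore expected to stay within the scatter, a 1.1-fold higher number from compound 3 to compound 4 (0.05 log units; within the scatter). Compound 4 is expected to give about 7000 nM in this assay, within a range from 2500 nM to 20000 nM.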

Compound 4, half-maximal inhibitory concentration: 10800 nM
Compound 4: the middle estimate sits 1.5-fold (0.19 log units) below what was measured; the range from low to high includes it.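

This pair is the only one shown that changes a group on the ring rather than swapping the whole ring for a chain. In this assay it reads a 1.8-fold higher number from compound 3 to compound 4 (0.24 log units; within the scatter) and so methyl and fluoro, on an aromatic carbon para to a large group, cannot be told apart here. The advantage of an aryl group over the chains also holds with fluoro on the ring, as an at least 7.4-fold lower number from compound 2 to compound 4 (0.86 log units; beyond the scatter) and an at least 7.4-fold lower number from compound 1 to compound 4 (0.86 log units; beyond the scatter) both show in this assay for this nitrogen substituent. The values of compound 1 and compound 2 are limits and not numbers, so these two steps give only a minimum size: (the limit of > 80000 nM in this assay, at which 2 of the 4 values shown sit).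

With only methyl and fluoro at this place, the compounds shown cannot say whether a larger or very different group there, such as methoxy, an amine or a carboxylic acid, would leave the number unchanged. They also leave open whether a plain phenyl ring with nothing on it would do as well, and whether a benzyl group, with one carbon between the ring and the nitrogen, would keep the advantage over the chains.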